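Piperidine Amide in Place of an Acid: Tolerability Outlook

A few compounds are considered here, and "the series" means these few. Any claim that something is new, unique, unknown or untested is made for them only; others in the source may bear on it.

compound 1 `CCOC(=O)c1oc2nc(-c3ccccc3)cc(C(F)(F)F)c2c1N` in an ADME assay on Huh-7 cells (Homo sapiens) for cytotoxicity, read by MTT assay, with a stated time of 72 h; a lower number here means that less compound is tolerated, a higher number that more compound is tolerated: > 20000 nM, a limit of the assay
compound 2 `Nc1c(C(=O)O)sc2nc(-c3ccccc3)cc(C(F)(F)F)c12` in this assay: > 20000 nM, a limit of the assay

Compound 2 carries a free carboxylic acid on the shared core. In this assay compound 2 gives only a limit, not a number, and it shares that standing with every other value shown here, as the limit of > 20000 nM in this assay, at which 2 of the 2 values shown sit, records. Nothing therefore separates compound 2 from compound 1 on these numbers; both simply lie at the edge of what the assay reports.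

Compound 3 `Nc1c(C(=O)N2CCCCC2)sc2nc(-c3ccccc3)cc(C(F)(F)F)c12` changes one group: piperidin-1-yl in place of hydroxy on a carbonyl carbon. Among the compounds with values here, no step between two measured compounds is available, so there is no measured precedent for what this swap does. With both measured compounds sitting at the limit, the expectation is for a step in this assay of no size beyond the usual scatter, in neither direction. Compound 3 is thus expected to give about 20000 nM, within a range from 7000 nM to 60000 nM. The expected step is a number no higher from compound 2 to compound 3 (the limit leaves the size open).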

Compound 3, half-maximal cytotoxic concentration: > 20000 nM
Compound 3: no number, only a limit; the forecaster's own chance of this, stated with the estimate: 65%; the middle value lies on the limit itself.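

In this assay compound 3 gives > 20000 nM, a limit of the assay and not a number. Compound 2 also gives only a limit, so no step can be read between compound 2 and compound 3. The compounds shown leave open how much of each compound is actually tolerated: the limit of > 20000 nM in this assay, at which 3 of the 3 values shown sit.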